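Isopropylsulfanyl for isobutylamino: a step from the limit

The source may report more compounds than this note shows. Statements on the series, on what has been measured and on what is new or still open speak of the compounds shown alone.

Of the compounds shown here, three sharing one core have been read in an ADME assay on CCRF-HSB-2 cells (Homo sapiens) for cytotoxicity, with a stated time of 7 days; on this read-out higher numbers stand for lower toxicity in this test and lower numbers for higher toxicity in this test. Compound 1 `CCOc1nc(N)nc2c1ncn2/C=C1/CC1(CO)CO` gives > 20000 nM, which is a limit and not a number. Compound 2 `COCCOc1nc(N)nc2c1ncn2/C=C1/CC1(CO)CO` gives > 20000 nM, again a limit. Compound 3 `CC(C)CNc1nc(N)nc2c1ncn2/C=C1/CC1(CO)CO` gives > 20000 nM, also a limit. None of the three has a number of its own, and the whole set stands at the limit of > 20000 nM in this assay, at which 3 of the 3 values shown sit.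

The next change leads to compound 4 `CC(C)Sc1nc(N)nc2c1ncn2/C=C1/CC1(CO)CO`, with isopropylsulfanyl in place of isobutylamino on an aromatic carbon.

Among the compounds with values here, three measured steps bear on this. Two of them swap the group on that same aromatic carbon: a step that the two limits leave unreadable from compound 1 to compound 3 and a step that the two limits leave unreadable from compound 2 to compound 3. The third lengthens the ether chain: a step that the two limits leave unreadable from compound 1 to compound 2. None of them has a readable size, so they give no direction and no magnitude to carry over. Three different groups on that carbon have so far all ended at the limit, and that is the only basis available. The estimated step is a number no higher from compound 3 to compound 4 (the limit leaves the size open), meaning that no change beyond the scatter is expected, in either direction. Compound 4 is expected to give 20000 nM, with an estimated range of 7000 nM to 50000 nM, and the most likely report is again only a limit.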

Compound 4, half-maximal cytotoxic concentration: 94000 nM
Beside the measured number, compound 4's estimate is 4.7-fold (0.67 log units) below it, and the stated range ends below it.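

No step to compound 4 can be read from compound 1, compound 2 or compound 3 in this assay, because each of those three results is a limit and not a number: the limit of > 20000 nM in this assay, at which 3 of the 4 values shown sit.

The compounds shown leave open whether isopropylsulfanyl on that aromatic carbon gives lower or higher toxicity in this test than ethoxy, 2-methoxyethoxy or isobutylamino.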